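The compounds below may be only part of what the source reports. "The series", "measured", "known", "first", "only" and "open" are said of these compounds alone.

Compounds measured so far in a functional assay on A 172 cells (Homo sapiens) for cytotoxicity, read by colorimetric assay and MTT assay; on this read-out higher numbers stand for weaker inhibition and lower numbers for stronger inhibition:
- compound 1 `COc1ccc2cc(-c3ccccc3)c(O)nc2c1`: 10000 nM
- compound 2 `COc1cc(OC)c2cc(-c3ccc(OCc4ccccc4)cc3)c(O)nc2c1`: 10000 nM
- compound 3 `COc1ccc(-c2cc3c(OC)cc(OC)cc3n(CC(=O)OCc3ccccc3)c2=O)cc1`: 10000 nM

All three compounds sit at the same level in this assay, so compound 3 stands neither ahead of nor behind the other two. The next compound, compound 4 `COc1ccc(-c2cc3c(OC)cc(OC)cc3n(CCC(=O)OCc3ccccc3)c2=O)cc1`, keeps most of compound 3 and alters one group: (benzyloxycarbonyl)methyl in place of benzyloxycarbonyl on a saturated chain carbon bound to an aromatic nitrogen. Counted out, the change is (benzyloxycarbonyl)methyl in place of benzyloxycarbonyl on a saturated chain carbon bound to an aromatic nitrogen.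

Within the data shown here, no measured pair differs in one place only, so the data show no direct example of what a single change does here. The expectation therefore rests on the closest relative, compound 3 at 10000 nM, and no step beyond the usual scatter is expected in either direction. The expected result is no change at the digits printed from compound 3 to compound 4 (within the scatter). The estimate for compound 4 is 10000 nM, with an expected range from 5000 nM to 20000 nM.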

Compound 4, half-maximal inhibitory concentration: 10000 nM
Compound 4: the middle estimate sits on the measured number at the digits printed, and the stated range covers the measured number.
By their numbers in this assay, from the lowest: compounds 1, 2, 3 and 4 (each within the scatter of the next).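

Compound 3 and compound 4 form the first pair shown that differs in one place, so they give a direct reading of a single change in this assay. Putting (benzyloxycarbonyl)methyl where benzyloxycarbonyl stood, on a saturated chain carbon bound to an aromatic nitrogen, gives no change at the digits printed from compound 3 to compound 4 (within the scatter), so this small extension leaves the read-out where it was. Nothing measured here offers an explanation for this result.

On these data alone, whether a different kind of group at this place, such as a carboxylic acid, an amine or a much longer chain, would shift the value remains open. Also open, as far as these compounds go, is which change anywhere on these compounds would give a lower number in this assay, since all four compounds share the same value.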